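Working notes: amides on one shared core, one compound unmeasured

The source may hold more compounds than are shown below. What is called first, only, known or untested is meant among the compounds shown, and "the series" means these compounds.

Compound 1 `O=C(Nc1ccc(Cl)cc1)c1cc([N+](=O)[O-])ccc1Cl`: in an ADME assay on Raji cells (Homo sapiens) for inhibition, with a stated time of 72 h (a lower number here means that less compound is needed, a higher number that more compound is needed for the effect), compound 1 gives > 25000 nM, a limit of the assay.
Compound 2 `C=CC(=O)Nc1cccc(-c2nc3ccccc3s2)c1`: in this assay compound 2 gives > 25000 nM, a limit of the assay.
Compound 3 `CN(C)CCC(=O)Nc1cccc(-c2nc3ccccc3s2)c1`: in this assay compound 3 gives > 25000 nM, a limit of the assay.

Compound 3 therefore stands only at a limit, as do the two other measured compounds; all three share (the limit of > 25000 nM in this assay, at which 3 of the 3 values shown sit). Going by the values given here, the one single-site step measured, a step that the two limits leave unreadable from compound 2 to compound 3, runs between two limits and its size cannot be read.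

Compound 4 `O=C(Nc1cccc(-c2nc3ccccc3s2)c1)c1ccc(Cl)nc1Cl` differs from compound 3 by 2,6-dichloropyridin-3-yl in place of 2-(dimethylamino)ethyl on a carbonyl carbon. Among the compounds with values here, the only measured step at the same carbonyl carbon is the unreadable one just named, so no step gives a readable size or direction for this change, and nothing shows a compound that leaves the limit.

In this assay compound 4 is expected to sit again at the limit or close to it, with an estimate of 30000 nM and a range from 8000 nM to 100000 nM. The step that the limit leaves unreadable from compound 3 to compound 4 is thus expected to be none beyond the scatter.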

Compound 4, half-maximal effective concentration: > 25000 nM
Compound 4: only a limit was reported; the forecaster's own chance of this, stated with the estimate: 70%; the middle value does not contradict the limit.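

Compound 4 gives > 25000 nM in this assay, a limit of the assay, so its steps from compound 2 and compound 3 cannot be read. The compounds shown leave open whether any group on the carbonyl carbon brings a value off the limit: the limit of > 25000 nM in this assay, at which 4 of the 4 values shown sit.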